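The source may report more compounds than this note shows. Statements on the series, on what has been measured and on what is new or still open speak of the compounds shown alone.

Three hydroxamic acids sharing one core have been measured in an assay on Sf9 cells for inhibition of protein deacetylase HDAC6 (Homo sapiens), read by mobility shift assay; a higher number here means a weaker inhibitor, a lower number a stronger inhibitor: compound 1 `CC(C)(C)c1ccc(CN(C(=O)CN(Cc2c(F)c(F)c(F)c(F)c2F)S(=O)(=O)c2ccc(F)cc2)c2ccc(C(=O)NO)cc2)cc1` gives 190 nM, compound 2 `O=C(NO)c1ccc(N(Cc2ccc(C(F)(F)F)cc2)C(=O)CN(Cc2c(F)c(F)c(F)c(F)c2F)S(=O)(=O)c2ccc(F)cc2)cc1` gives 86 nM, and compound 3 `CC(C)(C)c1ccc(CN(C(=O)CN(Cc2ccccc2C(F)(F)F)S(=O)(=O)c2ccc(F)c(F)c2)c2ccc(C(=O)NO)cc2)cc1` gives 362 nM. Compound 3 stands at the high end of these three numbers; its gap to compound 1 lies within the scatter, while its gap to compound 2 lies beyond it. Going by the values given here, the single step for which both ends are measured, a 2.2-fold lower number from compound 1 to compound 2 (0.34 log units; beyond the scatter), changed a group far from the sulfonyl. Among the compounds with values here, compound 4 `CC(C)(C)c1ccc(CN(C(=O)CN(Cc2ccccc2C(F)(F)F)S(=O)(=O)c2ccc(F)cc2F)c2ccc(C(=O)NO)cc2)cc1` differs from compound 3 only by 2,4-difluorophenyl in place of 3,4-difluorophenyl on a sulfonyl sulfur, a change on which no measured step bears. For compound 4 in this assay he therefore expects a 1.0-fold lower number from compound 3 to compound 4 (0.01 log units; within the scatter), nothing beyond the scatter. His estimate for compound 4 is 350 nM, ranging from 150 nM to 800 nM.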

Compound 4, half-maximal inhibitory concentration: 289 nM
For compound 4 the middle estimate is 1.2-fold (0.08 log units) above the measured one, and the stated range covers the measured number.
By their numbers in this assay, from the lowest: compound 2; then compounds 1, 4 and 3 (each within the scatter of the next).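

In this assay, 2,4-difluorophenyl in place of 3,4-difluorophenyl on a sulfonyl sulfur gives a 1.3-fold lower number from compound 3 to compound 4 (0.10 log units; within the scatter), so the two compounds cannot be told apart. Going by these compounds alone, this is the first reading at this position, and it shows that rearranging the same atoms of this ring leaves the number within the scatter, at least with the other groups of compound 3 in place. No evidence at hand bears on this result.

Still open, from the compounds shown here alone, is how a phenyl carrying an amine or a carboxylic acid would read on that sulfonyl sulfur. Also open, going by these compounds, is whether this swap would read alike among the other groups of compound 2.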